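The source may hold more compounds than are shown below. What is called first, only, known or untested is meant among the compounds shown, and "the series" means these compounds.

Measured compounds:
compound 1, `COC(=O)c1cc2ccccc2n1[C@@H]1c2cc(C#N)ccc2OC(C)(C)[C@H]1O`, 33000 nM in a functional assay (aorta) with Rattus norvegicus as the target; on this read-out higher numbers stand for weaker inhibition and lower numbers for stronger inhibition
compound 2, `CCOC(=O)CN(c1ccccc1)[C@H]1c2cc(C#N)ccc2OC(C)(C)[C@@H]1O`, > 30000 nM in this assay, which is a limit of the assay and not a number
compound 3, `CC1(C)Oc2ccc(C#N)cc2[C@H](Nc2ccccc2)[C@H]1O`, 1200 nM in this assay

Among the numbers shown, compound 3 stands lowest in this assay; the nearest number is that of compound 1, which lies higher by a gap beyond the scatter. Compound 2 sits at the limit of this assay, a fact recorded as the limit of > 30000 nM in this assay, at which 1 of the 3 values shown sits.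

Compound 4, `CC1(C)Oc2ccc(C#N)cc2[C@H](N(CC(=O)O)c2ccccc2)[C@H]1O`, has not yet been measured in this assay. It differs from compound 3 in one place: carboxymethyl in place of hydrogen on a nitrogen on an aromatic ring.

For the measured compounds named here, one measured step bears on this change. Going an at least 25-fold lower number from compound 2 to compound 3 (1.39 log units; beyond the scatter), the removal of a substituent of similar build from the same nitrogen gave a large drop in the number. The step to compound 4 runs in the opposite sense, adding a carboxymethyl where compound 3 carries a hydrogen, so a large rise is expected in this assay, of about a 21-fold higher number from compound 3 to compound 4 (1.32 log units; beyond the scatter). Compound 4 is therefore estimated at 25000 nM, within a range from 6000 nM to 100000 nM, with a real chance that only a limit is reported.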

Compound 4, half-maximal inhibitory concentration: > 100000 nM
Compound 4 was reported as a limit; the forecaster's own chance of this, stated with the estimate: 40%; middle value at least 4.0-fold (0.60 log units) from the limit.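

Placing carboxymethyl on the nitrogen of compound 3 gave, in this assay, an at least 83-fold higher number from compound 3 to compound 4 (1.92 log units; beyond the scatter), so the loss seen earlier with the ethyl ester on this nitrogen also appears with the free carboxylic acid and is not confined to the ester form of the chain. Compound 4 stands at a limit of the assay, which is not a number: the limit of > 100000 nM in this assay, at which 1 of the 4 values shown sits. Compound 2 also stands at a limit, so the step between the ethyl ester and the acid cannot be read, and the two forms cannot be ranked against each other: the limit of > 30000 nM in this assay, at which 1 of the 4 values shown sits.

The compounds shown hold only hydrogen or chains ending in a carbonyl group on this nitrogen, so they leave open whether a plain methyl or a longer alkyl chain without a carbonyl would raise the number as far. They also leave open whether a primary amide or an amine at the end of the chain would behave like the acid in this assay, and how small a substituent on this nitrogen must be to keep the standing of compound 3.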